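Anilino-Quinoxaline Sulfones: Moving an Amino Group Around

The source may report more compounds than this note shows. Statements on the series, on what has been measured and on what is new or still open speak of the compounds shown alone.

This set of compounds shares one core, seen in compound 1 `COc1ccc(Nc2nc3ccccc3nc2S(=O)(=O)c2ccccc2)cc1`, and differs only in the ring carried on the anilino nitrogen. Cytotoxicity was followed in a functional assay on KB cells (Homo sapiens) for cytotoxicity, read by MTT assay, with a stated time of 72 h; on this read-out lower numbers stand for stronger inhibition and higher numbers for weaker inhibition. For compound 1 the result reads "not determined" (no result reported), so compound 1 stands without a number of its own. The same holds for compound 2 `COc1cc(Nc2nc3ccccc3nc2S(=O)(=O)c2ccccc2)cc(OC)c1OC`, whose entry in this assay is "not determined" (no result reported). Only compound 3 `Nc1ccc(Nc2nc3ccccc3nc2S(=O)(=O)c2ccccc2)cc1` carries a number, giving 3400 nM in this assay.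

Compound 4 `Nc1cccc(Nc2nc3ccccc3nc2S(=O)(=O)c2ccccc2)c1` is reached from compound 1 by a single change: 3-aminophenyl in place of 4-methoxyphenyl on a nitrogen on an aromatic ring. Whether this step moves this assay beyond the scatter cannot be said, as compound 1 has no number to compare against. The closest measured point is compound 3, which differs from compound 4 only in where the amino group sits on the ring; in this assay compound 3 gives 3400 nM. Compound 4 is therefore expected to come out near that level, at about 4000 nM, with a plausible range from 1500 nM to 12000 nM.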

Compound 4, half-maximal inhibitory concentration: 4290 nM
The estimate for compound 4 lay 1.1-fold (0.03 log units) below the measured number; measured number inside the range.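

Shifting the amino group, with 3-aminophenyl in place of 4-aminophenyl on a nitrogen on an aromatic ring, gives a 1.3-fold higher number from compound 3 to compound 4 (0.10 log units; within the scatter) in this assay for this pair. Among these compounds, this is the first pair in the set with a number on both sides, and on this read-out the two placements of the amino group cannot be told apart. Nothing measured here offers an explanation for how closely the two compounds read.

Among the compounds shown here, compound 1 and compound 2 hold no number, so no step that involves either of them can be read, and the methoxy-bearing rings stay uncompared with the amino-bearing ones. Also open, on these data alone, is what would happen on this ring if a hydroxyl group, a carboxylic acid or a dimethylamino group took the place of the amino group.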